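The source may hold more compounds than are shown below. What is called first, only, known or untested is meant among the compounds shown, and "the series" means these compounds.

In an ADME assay on a cell-free system (plasma, Rattus norvegicus, strain Sprague-Dawley) for metabolic stability, read by LC-MS, tested at 10 uM (on this read-out lower numbers stand for a shorter-lived compound and higher numbers for a longer-lived compound), compound 2 `COc1ccc2c(c1)C(C)CN(CC(=O)NO)S2(=O)=O` gives 10.5 h, the lowest of the two numbers recorded so far; compound 1 `O=C(NO)C1(C(=O)NCc2ccc(F)cc2)CC1` gives 22.3 h, a gap beyond the usual scatter. Compound 3 `CC1CN(CC(=O)NO)S(=O)(=O)c2ccccc21` has not yet been measured. It differs from compound 2 in one place: hydrogen in place of methoxy on an aromatic carbon. For the measured compounds named here, no measured pair shows this change, so there is no precedent to draw on. The step is expected to be small, a 1.1-fold lower number from compound 2 to compound 3 (0.02 log units; within the scatter), within the scatter and in no clear direction. Compound 3 is therefore expected to give 10 h, with a range from 5 h to 20 h.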

Compound 3, half-life: 9.6 h
The estimate for compound 3 lay 1.0-fold (0.02 log units) above the measured number, within the range that was stated.
By their numbers in this assay, from the lowest: compounds 3 and 2 (each within the scatter of the next); then compound 1.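

In this assay, for the compounds shown here, this pair gives the first direct reading of this change: hydrogen in place of methoxy on this aromatic carbon gives a 1.1-fold lower number from compound 2 to compound 3 (0.04 log units; within the scatter). The two numbers cannot be told apart, so the methoxy is not required at this position for a half-life of this order. No evidence on the reason accompanies this result.

The compounds shown leave open whether other groups on this carbon, such as an amine, a carboxylic acid or a longer chain, would read the same. They also leave open whether the same change would read alike elsewhere on the aromatic ring.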